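Cyano for chloro on the isopropoxy-bearing ring

The source may hold more compounds than are shown below. What is called first, only, known or untested is meant among the compounds shown, and "the series" means these compounds.

Compound 2 `Cc1cc(CCC(=O)O)ccc1-c1noc(-c2ccc(OC(C)C)c(Cl)c2)n1` has been run in a functional assay on CHO cells with sphingosine 1-phosphate receptor 4 (Homo sapiens) as the target, read by GTPgammaS binding; on this read-out lower numbers stand for an effect already at smaller amounts and higher numbers for an effect only at larger amounts of compound. In that assay compound 2 returns only the assay limit, > 10000 nM, and no number. Compound 1 `COc1ccc(-c2nc(-c3ccc(CCC(=O)O)cc3C)no2)cc1C(F)(F)F` likewise gives only a limit in this assay, > 10000 nM. Both values shown thus sit at the limit of > 10000 nM in this assay, at which 2 of the 2 values shown sit, so compound 2 cannot be ranked against compound 1: the two values show nothing beyond a shared limit. For the measured compounds named here, no measured step between compounds is available.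

The next compound is compound 3 `Cc1cc(CCC(=O)O)ccc1-c1noc(-c2ccc(OC(C)C)c(C#N)c2)n1`. Its difference from compound 2 is cyano in place of chloro on an aromatic carbon. The expected change from compound 2 to compound 3 is a step that the limit leaves unreadable from compound 2 to compound 3, no shift beyond the scatter, and most likely another limit rather than a number. Compound 3 is accordingly expected near 15000 nM, in the range 5000 nM to 50000 nM.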

Compound 3, half-maximal effective concentration: > 10000 nM
Compound 3 was reported as a limit; the forecaster's own chance of this, stated with the estimate: 80%; the middle value does not contradict the limit.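

Compound 3 gives only a limit in this assay, > 10000 nM, and no step can be read from compound 2 to compound 3: the limit of > 10000 nM in this assay, at which 3 of the 3 values shown sit.

Whether cyano in place of chloro on an aromatic carbon changes the effect at all stays open, as does any ranking of these compounds.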